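Hydroxy-to-amino exchange on two chromenyl ketone cores

The compounds below may be only part of what the source reports. "The series", "measured", "known", "first", "only" and "open" are said of these compounds alone.

Measured so far in a functional assay on A2780 cells (Homo sapiens) for antiproliferative activity, read by MTT assay, with a stated time of 48 h; on this read-out higher numbers stand for weaker inhibition and lower numbers for stronger inhibition:
compound 1 `COc1ccc(C(=O)c2ccc(OC)c3c2OC(C)(C)C=C3)c(NC(=O)CO)c1`: 100 nM
compound 2 `COc1ccc(C(=O)c2ccc3c(c2)C=CC(C)(C)O3)c(NC(=O)CO)c1`: 130 nM
compound 3 `COc1ccc(C(=O)c2ccc(OC)c3c2OC(C)(C)C=C3)c(NC(=O)CN)c1`: 380 nM

Compound 1 and compound 2 carry different cores; the difference between the two cores is not broken down here, and in this assay compound 2 gives 130 nM, which lies within the scatter of compound 1. Compound 3 carries the core of compound 1 with amino in place of hydroxy on a saturated chain carbon bound to a carbonyl carbon; this change gives a 3.8-fold higher number from compound 1 to compound 3 (0.58 log units; beyond the scatter).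

Compound 4 `COc1ccc(C(=O)c2ccc3c(c2)C=CC(C)(C)O3)c(NC(=O)CN)c1` is not yet measured. It stands to compound 2 as compound 3 stands to compound 1, through (amino in place of hydroxy on a saturated chain carbon bound to a carbonyl carbon), the same change at the same place.

For compound 4 the expected step is a 3.7-fold higher number from compound 2 to compound 4 (0.57 log units; beyond the scatter), resting on a 3.8-fold higher number from compound 1 to compound 3 (0.58 log units; beyond the scatter) seen on the other core. Compound 4 is therefore estimated at 480 nM, with the expected range running from 240 nM to 1000 nM.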

Compound 4, half-maximal inhibitory concentration: 590 nM
Estimate against measurement, compound 4: 1.2-fold (0.09 log units) below, and the stated range covers the measured number.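

In this assay, amino in place of hydroxy on a saturated chain carbon bound to a carbonyl carbon gives a 4.5-fold higher number from compound 2 to compound 4 (0.66 log units; beyond the scatter), and the step carries from one core to the other with no change in size beyond the scatter: the same change on two cores in this assay, a 3.8-fold higher number (0.58 log units; beyond the scatter) from compound 1 to compound 3 and a 4.5-fold higher number (0.66 log units; beyond the scatter) from compound 2 to compound 4, 1.2-fold (0.08 log units) apart, within the scatter of two such steps. This rests on two cores in one assay, so it shows that the change transferred between these two cores, not that it would do so on any other core. Nor does it show why compound 3 and compound 4 give the higher numbers.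

As far as these compounds go, it remains open whether a dimethylamino or methoxy group in the same place would follow the amino group or the hydroxy group. From the compounds shown here alone, a longer chain carrying the hydroxy or amino group also remains open.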